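This account rests on a few compounds, and the source may have more. Where it says the series, first, only, none or still open, it means among the compounds named here.

Compound 1 `COc1ccc(OC)c(-c2cc(-c3ccc(Cl)cc3)nn2-c2ccc(S(=O)(=O)NC(C)=O)cc2)c1`: 17700 nM
Compound 2 `NS(=O)(=O)c1ccc(-n2nc(-c3ccc(Cl)cc3)cc2-c2cc(O)ccc2O)cc1`: 13000 nM
Compound 3 `CC(=O)NS(=O)(=O)c1ccc(-n2nc(-c3ccccc3)cc2-c2cc(O)ccc2O)cc1`: 93900 nM

These three compounds were tested in a functional assay on cells (Cancer cell lines, Homo sapiens) for cytotoxicity, read by sulforhodamine B assay, with a stated time of 48 h; on this read-out higher numbers stand for weaker inhibition of growth and lower numbers for stronger inhibition of growth. Compound 3 holds the highest number of the three; compound 1 lies nearest, with its 17700 nM a step below that goes beyond the scatter, while compound 2 with its 13000 nM lies furthest, also beyond the scatter.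

Compound 4 `CC(=O)NS(=O)(=O)c1ccc(-n2nc(-c3ccc(Cl)cc3)cc2-c2cc(O)ccc2O)cc1` has not yet been measured in this assay. It differs from compound 3 in one place: chloro in place of hydrogen on an aromatic carbon. Among the measured compounds shown here, since no measured pair shows this change alone, its size is uncertain, but compound 1 and compound 2, which both carry the chlorophenyl, sit well below compound 3. The expected step from compound 3 to compound 4 is therefore a drop beyond the scatter, a 4.7-fold lower number from compound 3 to compound 4 (0.67 log units; beyond the scatter). Compound 4 is estimated at 20000 nM, in the range 8000 nM to 60000 nM.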

Compound 4, concentration for 50% growth inhibition: 36200 nM
For compound 4 the middle estimate is 1.8-fold (0.26 log units) below the measured one; measured number inside the range.
By their numbers in this assay, from the lowest: compounds 2 and 1 (each within the scatter of the next); then compound 4; then compound 3.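

In this assay, phenyl to 4-chlorophenyl taken alone gives a 2.6-fold lower number from compound 3 to compound 4 (0.41 log units; beyond the scatter), a modest step that shows chloro para to a large group counts on its own. Chloro does not settle the number, since acetyl in place of hydrogen on the sulfonamide nitrogen gives a 2.8-fold higher number from compound 2 to compound 4 (0.44 log units; beyond the scatter) and 2,5-dihydroxyphenyl in place of 2,5-dimethoxyphenyl gives a 2.0-fold higher number from compound 1 to compound 4 (0.31 log units; beyond the scatter). Nothing available explains these steps. On these data alone, whether fluoro, methoxy or an amine at this place would move the number further stays open. So does whether chloro gives a step of the same size with the other two end groups.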